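This account rests on a few compounds, and the source may have more. Where it says the series, first, only, none or still open, it means among the compounds named here.

Measured in a functional assay on HepG2 cells (Homo sapiens) for antiproliferative activity, read by MTT assay, with a stated time of 48 h; on this read-out lower numbers stand for stronger inhibition and higher numbers for weaker inhibition:
- Compound 1 `CCn1cc(-c2nc3ccc([N+](=O)[O-])cc3o2)c(=O)c2cc(F)c(N3CCNC(C)C3)c(F)c21`: 2650 nM
- Compound 2 `CCn1cc(-c2ccc(Cl)cc2)c(=O)c2cc(F)c(N3CCNCC3)cc21`: 24000 nM
- Compound 3 `CCn1cc(-c2ccc(OC)cc2)c(=O)c2cc(F)c(N3CCNCC3)cc21`: 57900 nM

Compound 2 holds the second highest of these three numbers, with compound 1 lower and compound 3 higher. The next compound, compound 4 `CCn1cc(-c2cccc(F)c2)c(=O)c2cc(F)c(N3CCNCC3)cc21`, has 3-fluorophenyl in place of 4-chlorophenyl on an aromatic carbon.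

For the measured compounds named here, only one measured step touches this same aromatic carbon: a change of the chloro group to methoxy gave a 2.4-fold higher number from compound 2 to compound 3 (0.38 log units; beyond the scatter). Going by the values given here, compound 1 differs from compound 2 in more than one place and offers no comparable step. Among the compounds with values here, no measured compound carries a 3-fluorophenyl group, so the single step is only an indirect guide. A change no larger than that modest step seems likely, leaning toward a higher number in this assay. The expected step is a 1.5-fold higher number from compound 2 to compound 4 (0.16 log units; within the scatter). For compound 4 the estimated value is 35000 nM, with an expected range from 14000 nM to 85000 nM.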

Compound 4, half-maximal inhibitory concentration: 27800 nM
Beside the measured number, compound 4's estimate is 1.3-fold (0.10 log units) above it; the range from low to high includes it.
By their numbers in this assay, from the lowest: compound 1; then compounds 2 and 4 (each within the scatter of the next); then compound 3.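

In this assay, replacing 4-chlorophenyl with 3-fluorophenyl gives a 1.2-fold higher number from compound 2 to compound 4 (0.06 log units; within the scatter), so these two groups cannot be told apart at this aromatic carbon. The 4-methoxyphenyl group of compound 3 now stands apart from both halogen-bearing groups, as the new comparison gives a 2.1-fold lower number from compound 3 to compound 4 (0.32 log units; beyond the scatter), in the same direction as the earlier step from chloro to methoxy. The information at hand offers nothing that accounts for this difference.

On these data alone, whether the identity of the halogen or its place on the phenyl matters more stays open; 4-fluorophenyl and 3-chlorophenyl would separate the two. Also open, as far as these compounds go, is how a phenyl carrying an amine or a carboxylic acid would read at this carbon in this assay.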